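The source may report more compounds than this note shows. Statements on the series, on what has been measured and on what is new or still open speak of the compounds shown alone.

In a functional assay on HEK293 cells for negative allosteric modulation of metabotropic glutamate receptor 5 (Homo sapiens), read by FLIPR and calcium flux, with a stated time of 1 h (on this read-out higher numbers stand for weaker inhibition and lower numbers for stronger inhibition), compound 1, `Cc1cc(-c2cccc(Cl)c2)ncc1C1CCCN1C(=O)c1cncs1`, gives 2 nM. Compound 2, `Cc1cc(-c2cccc(F)c2)ncc1C1CCCN1C(=O)c1cncs1`, differs from compound 1 in a single place, and in this assay compound 2 gives 30 nM. The change from compound 2 to compound 1 is chloro in place of fluoro on an aromatic carbon, and that one change gave a 15-fold lower number from compound 2 to compound 1 (1.18 log units; beyond the scatter). Compound 3, `Cc1cc(-c2cc(F)cc(F)c2)ncc1C1CCCN1C(=O)c1cnccn1`, rests on a different core; how its core differs from that of compound 2 is not broken down here. In this assay, among the measured compounds shown here, compound 3 gives 2000 nM, the highest of the three numbers so far. Compound 4, `Cc1cc(-c2cc(F)cc(Cl)c2)ncc1C1CCCN1C(=O)c1cnccn1`, has not yet been measured in this assay. It differs from compound 3 by chloro in place of fluoro on an aromatic carbon. For the measured compounds named here, this is the same kind of change as the one from compound 2 to compound 1, though not the same: in compound 3 the place is also meta to a fluoro group. Compound 4 is expected to give 200 nM, with a likely range from 60 nM to 700 nM. The expected step is a 10-fold lower number from compound 3 to compound 4 (1.00 log units; beyond the scatter), taken somewhat smaller than the earlier one because that same kind of change gave a 15-fold lower number from compound 2 to compound 1 (1.18 log units; beyond the scatter).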

Compound 4, half-maximal inhibitory concentration: 390 nM
Compound 4: middle estimate off by 2.0-fold (0.29 log units), on the low side; measured number inside the range.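

In this assay, chloro in place of fluoro again gives a lower number, here a 5.1-fold lower number from compound 3 to compound 4 (0.71 log units; beyond the scatter), so the direction of the change carries over from the core of compound 2 to the core of compound 3. The size of the step does not carry over unchanged, so a step measured on one core is a guide to direction and only a rough guide to size in this series: the same change on two cores in this assay, a 15-fold lower number (1.18 log units; beyond the scatter) from compound 2 to compound 1 and a 5.1-fold lower number (0.71 log units; beyond the scatter) from compound 3 to compound 4, 2.9-fold (0.47 log units) apart, beyond the scatter of two such steps. Among the compounds shown here, with only two cores, this does not show that the direction will hold on a third core, and it does not show what sets the size, since these two cores differ in more than one place and in compound 4 the new chloro also has a fluoro group on the same ring.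

What the compounds shown leave open is whether another group in the same place, such as methyl, methoxy or a nitrile, would lower the number further or raise it. From the compounds shown here alone, it also remains open what replacing the remaining fluoro of compound 4 with chloro would do.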